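Swapping a Benzyl Group: From Measured Pairs to an Expectation

The source may report more compounds than this note shows. Statements on the series, on what has been measured and on what is new or still open speak of the compounds shown alone.

Compound 1 `Cc1ccc(Cn2c(/C=C3\SC(=S)N(CC(=O)O)C3=O)nc3cc(Cl)ccc32)cc1` gives 21400 nM in a functional assay on HeLa cells (Homo sapiens) for cytotoxicity, read by MTT assay, with a stated time of 48 h; a higher number here means a weaker inhibitor, a lower number a stronger inhibitor.
Compound 2 `Cc1ccc(Cn2c(/C=C3\SC(=S)NC3=O)nc3ccccc32)cc1` gives 25300 nM in this assay.
Compound 3 `O=C(O)CN1C(=O)/C(=C/c2nc3cc(Cl)ccc3n2Cc2ccccc2F)SC1=S` gives 9520 nM in this assay.

Compound 1 and compound 3 share the same core and differ in one place: 2-fluorophenyl in place of 4-methylphenyl on a saturated chain carbon bound to an aromatic nitrogen. This change gave a 2.2-fold lower number from compound 1 to compound 3 (0.35 log units; beyond the scatter), a modest improvement that is nonetheless larger than what repeated measurements would usually produce by chance.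

Compound 2 has a different core from compound 1; the difference between the two cores is not broken down here. Compound 2 gives the highest of the three numbers, but compound 1 lies so close to it that no order between the two can be claimed. Compound 3, by contrast, sits clearly lower than compound 2.

Compound 4 `O=C1NC(=S)S/C1=C\c1nc2ccccc2n1Cc1ccccc1F` has not yet been measured. It carries the same change relative to compound 2 that compound 3 carries relative to compound 1: 2-fluorophenyl in place of 4-methylphenyl on a saturated chain carbon bound to an aromatic nitrogen. Since the change sits in the same place in both pairs, it is the same change, applied to a different core.

The expectation for compound 4 rests on a single measured pair, so it is tentative. Because compound 1 to compound 3 gave a 2.2-fold lower number from compound 1 to compound 3 (0.35 log units; beyond the scatter), compound 4 is expected to show a step of about a 2.2-fold lower number from compound 2 to compound 4 (0.34 log units; beyond the scatter) from compound 2. On that basis, compound 4 is estimated at 11500 nM in this assay, with a likely range from 5000 nM to 28000 nM.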

Compound 4, half-maximal inhibitory concentration: 36100 nM
For compound 4 the middle estimate is 3.1-fold (0.50 log units) below the measured one; the whole stated range lies below it.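

In this assay, the swap from 4-methylbenzyl to 2-fluorobenzyl does not carry over unchanged from one core to the other: the same change on two cores in this assay, a 2.2-fold lower number (0.35 log units; beyond the scatter) from compound 1 to compound 3 and a 1.4-fold higher number (0.15 log units; within the scatter) from compound 2 to compound 4, 3.2-fold (0.51 log units) apart, beyond the scatter of two such steps. On the second core the swap gives a 1.4-fold higher number from compound 2 to compound 4 (0.15 log units; within the scatter), so the two values there cannot be told apart, and the modest gain seen on the first core does not appear. Among the compounds shown here, this shows that a step measured on one core is a poor guide to the same step on another, but with only two pairs it gives no general rule, and it does not show what sets the two cores apart, as the core of compound 1 carries both a chlorine and a carboxylic acid chain that the core of compound 2 lacks.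

The compounds shown leave open how the swap behaves on a core with the chlorine alone or with the carboxylic acid chain alone, which would be needed to tie the difference to one of the two. Also open, going by these compounds, is whether the swap would hold up with an amine, or with a longer chain ending in a carboxylic acid, in place of that chain.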